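Ortho fluoro on the biaryl ring of the series

The compounds below may be only part of what the source reports. "The series", "measured", "known", "first", "only" and "open" are said of these compounds alone.

Of the compounds shown here, three have been measured in an assay on CHO-K1 cells for displacement of a labelled ligand from 5-hydroxytryptamine receptor 7 (Homo sapiens), read by scintillation counting; on this read-out lower numbers stand for stronger inhibition and higher numbers for weaker inhibition. Compound 1 `COc1ccccc1N1CCN(CCCCC(=O)NCc2ccccc2-c2cccc(F)c2)CC1` gives 34.7 nM, compound 2 `COc1ccccc1N1CCN(CCCCC(=O)NCc2ccccc2-c2ccccc2C)CC1` gives 26.1 nM, and compound 3 `COc1ccccc1N1CCN(CCCCC(=O)NCc2ccccc2-c2ccccc2)CC1` gives 37.9 nM. Among the measured compounds shown here, compound 3 carries the highest number of the three, but the gaps are small: a 1.1-fold higher number from compound 1 to compound 3 (0.04 log units; within the scatter), and a 1.5-fold higher number from compound 2 to compound 3 (0.16 log units; within the scatter), so no compound can be set apart from the others.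

The next step goes from compound 3 to compound 4 `COc1ccccc1N1CCN(CCCCC(=O)NCc2ccccc2-c2ccccc2F)CC1`: fluoro in place of hydrogen on an aromatic carbon. Two measured steps speak to it. The step of a 1.1-fold higher number from compound 1 to compound 3 (0.04 log units; within the scatter) removes a fluoro from the same ring, though from a different position, and the step of a 1.5-fold higher number from compound 2 to compound 3 (0.16 log units; within the scatter) removes a small group from the position ortho to the large group that compound 4 will now hold a fluoro on. Both are within the scatter, and the step of a 1.3-fold lower number from compound 1 to compound 2 (0.12 log units; within the scatter), which swaps the two substituted rings, is as well. Nothing in the series therefore points to a shift beyond the scatter in this assay, in either direction.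

Compound 4 is thus expected to give about 30 nM, with a range from 15 nM to 60 nM, a step of a 1.3-fold lower number from compound 3 to compound 4 (0.10 log units; within the scatter) that is estimated to stay within the usual scatter.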

Compound 4, inhibition constant: 36.5 nM
For compound 4 the middle estimate is 1.2-fold (0.09 log units) below the measured one; the measured number falls inside the stated range.
By their numbers in this assay, from the lowest: compounds 2, 1, 4 and 3 (each within the scatter of the next).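

In this assay, the change from phenyl to 2-fluorophenyl, with fluoro ortho to a large group, is now read directly as a 1.0-fold lower number from compound 3 to compound 4 (0.02 log units; within the scatter) and gives this position a same-site comparison of hydrogen and fluoro on the otherwise unsubstituted ring. The same position also has a direct comparison of methyl and fluoro, a 1.4-fold higher number from compound 2 to compound 4 (0.15 log units; within the scatter), and the placement of fluoro on the ring can be compared through a 1.1-fold higher number from compound 1 to compound 4 (0.02 log units; within the scatter), with 2-fluorophenyl in place of 3-fluorophenyl. Across these comparisons, neither the identity of this small substituent nor the tested fluoro placement separates the compounds in this binding measurement, and no supporting measurement bears on the result.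

On these data alone, whether a larger or charged group at this position, such as trifluoromethyl, methoxy, an amine or a carboxylic acid, would move the number beyond the scatter remains open. Also open, as far as these compounds go, is whether a longer chain in the shared core would change the response to these substituents, as all four compounds keep that part of the structure unchanged.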